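This account rests on a few compounds, and the source may have more. Where it says the series, first, only, none or still open, it means among the compounds named here.

Compound 1 `Cc1nc(S(C)(=O)=O)ccc1Oc1ncnc(OC2CCN(C(=O)OC(C)(C)C(F)(F)F)CC2)c1F` — 47.2 nM
Compound 2 `CCC1(OC(=O)N2CCC(Oc3ncnc(Oc4ccc(S(C)(=O)=O)nc4C)c3F)CC2)CC1` — 333 nM
Compound 3 `Cc1nc(S(C)(=O)=O)ccc1Oc1ncnc(OC2CCN(C(=O)OC3(C(F)(F)F)COC3)CC2)c1F` — 342 nM

All three were measured in a functional assay on isolated protein for inhibition of Glucose-dependent insulinotropic receptor (Rattus norvegicus), read by HTRF and cAMP accumulation; on this read-out lower numbers stand for an effect already at smaller amounts and higher numbers for an effect only at larger amounts of compound. Compound 1 gives the lowest number of the three, and the other two lie clearly higher: a 7.1-fold higher number from compound 1 to compound 2 (0.85 log units; beyond the scatter) and a 7.2-fold higher number from compound 1 to compound 3 (0.86 log units; beyond the scatter). Compound 4 `Cc1nc(S(C)(=O)=O)ccc1Oc1ncnc(OC2CCN(C(=O)SC(C)(C)C)CC2)c1F` differs from compound 1 in a single place: (tert-butyl)sulfanyl in place of 1-methyl-1-(trifluoromethyl)ethoxy on a carbonyl carbon. Among the compounds with values here, no measured step exchanges the oxygen on that carbonyl carbon for sulfur, but the two measured changes to the group attached there both pushed the number up by a modest amount. A rise of similar or somewhat smaller size is therefore expected for compound 4, a 2.8-fold higher number from compound 1 to compound 4 (0.44 log units; beyond the scatter). Compound 4 is estimated at 130 nM, with a likely range from 40 nM to 450 nM.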

Compound 4, half-maximal effective concentration: 30.7 nM
For compound 4 the middle estimate is 4.2-fold (0.63 log units) above the measured one, outside the stated range (below it).
By their numbers in this assay, from the lowest: compounds 4 and 1 (each within the scatter of the next); then compounds 2 and 3 (each within the scatter of the next).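

Replacing 1-methyl-1-(trifluoromethyl)ethoxy with (tert-butyl)sulfanyl on this carbonyl carbon leaves no readable change in this assay (a 1.5-fold lower number from compound 1 to compound 4 (0.19 log units; within the scatter)). The new group also stands well apart from the other two groups (an 11-fold lower number from compound 3 to compound 4 (1.05 log units; beyond the scatter); an 11-fold lower number from compound 2 to compound 4 (1.04 log units; beyond the scatter)), so this position accepts a sulfur link and a group without fluorine. Nothing available gives a reason for this.

Open, going by these compounds, is how plain tert-butoxy would compare here, which would separate the effect of sulfur from that of losing fluorine. Also open, on these data alone, is how an amine or a longer chain would fare on this carbonyl carbon.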